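Acetamido for methyl on the biaryl: compound 4 expected

A few compounds are considered here, and "the series" means these few. Any claim that something is new, unique, unknown or untested is made for them only; others in the source may bear on it.

In an assay on COS-7 cells for inhibition of patatin-like phospholipase domain-containing protein 2 (Mus musculus), tested at 200 uM (on this read-out lower numbers stand for less inhibition and higher numbers for more inhibition at the one concentration tested (going by the name of the read-out)), compound 1 `CCOC(=O)c1ccc(-c2ccc(OCC)cc2)o1` gives 93%, compound 2 `CCOC(=O)c1cccc(-c2cccs2)c1` gives 55%, and compound 3 `CCOc1ccc(-c2cccc(C)c2)cc1` gives 54%. Compound 3 holds the lowest of the three numbers; its nearest neighbour is compound 2, whose value sits within the scatter of it, while compound 1 lies beyond the scatter above it. For the measured compounds named here, no pair of measured compounds differs in one place, so no measured step is known. Compound 4 `CCOc1ccc(-c2cccc(NC(C)=O)c2)cc1` follows from compound 3 by acetamido in place of methyl on an aromatic carbon. Going by the values given here, with no comparable step in hand, a step in this assay of at most moderate size is expected, in either direction, or none beyond the scatter. Compound 4 is estimated at 50%, with a range from 25% to 75%. This corresponds to an expected step of a number 4 percentage points lower from compound 3 to compound 4 (within the scatter).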

Compound 4, a percentage reported as inhibition, at one concentration (the size of the read-out at that concentration, not a potency): 52%
The estimate for compound 4 lay 2 percentage points below the measured number, within the range that was stated.
By their numbers in this assay, from the lowest: compounds 4, 3 and 2 (each within the scatter of the next); then compound 1.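

In this assay, for the compounds shown here, acetamido in place of methyl on an aromatic carbon gives a number 2 percentage points lower from compound 3 to compound 4 (within the scatter), the first step that can be read from one change. This position, meta to a group of 9 heavy atoms, therefore accepts the larger acetamido group, with its hydrogen-bond donor and acceptor, without a shift beyond the scatter. Nothing at hand explains why the two groups read alike. On these data alone, whether an amine, a carboxylic acid or a longer chain on this carbon would read alike remains open, as does whether the same change would behave this way on the core of compound 1.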